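The compounds below may be only part of what the source reports. "The series", "measured", "known", "first", "only" and "open" are said of these compounds alone.

For the measured compounds named here, in a functional assay on cells (Cancer cell lines, Homo sapiens) for cytotoxicity, read by sulforhodamine B assay, with a stated time of 48 h (on this read-out higher numbers stand for weaker inhibition of growth and lower numbers for stronger inhibition of growth), compound 2 `COc1ccc(C2=NN(C3=NC(=O)/C(=C4\C(=O)Nc5ccccc54)S3)C(c3ccc(Cl)cc3)C2)cc1` gives 100000 nM, the higher of the two numbers so far; compound 1 `COc1ccc(C2CC(c3ccc4ccccc4c3)=NN2C2=NC(=O)/C(=C3\C(=O)Nc4ccccc43)S2)cc1` gives 13600 nM, a lower number by a margin beyond the scatter. Compound 3 `O=C1N=C(N2N=C(c3ccc4ccccc4c3)CC2c2ccc(Cl)cc2)S/C1=C1/C(=O)Nc2ccccc21` carries naphthalen-2-yl in place of 4-methoxyphenyl on a carbon with a double bond to nitrogen, so it holds the naphthalen-2-yl group of compound 1 together with the 4-chlorophenyl group of compound 2. A move toward lower numbers in this assay is expected because compound 1 with that naphthalen-2-yl group gives 13600 nM. The step from compound 2 to compound 3 is expected to be a 4.0-fold lower number from compound 2 to compound 3 (0.60 log units; beyond the scatter). Compound 3 is estimated at 25000 nM, within 6000 nM to 100000 nM.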

Compound 3, concentration for total growth inhibition: 42100 nM
The estimate for compound 3 lay 1.7-fold (0.23 log units) below the measured number; measured number inside the range.
By their numbers in this assay, from the lowest: compound 1; then compound 3; then compound 2.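

For the compounds shown here, with the 4-chlorophenyl group held, the step to naphthalen-2-yl in place of 4-methoxyphenyl on a carbon with a double bond to nitrogen is a 2.4-fold lower number from compound 2 to compound 3 (0.38 log units; beyond the scatter) in this assay and gives the first direct reading at this position. With naphthalen-2-yl held, chloro in place of methoxy on an aromatic carbon is a 3.1-fold higher number from compound 1 to compound 3 (0.49 log units; beyond the scatter) and shows that the number also shifts with this second place. As far as these compounds go, how an amine or a carboxylic acid would fare on that carbon with a double bond to nitrogen remains open. Nothing at hand explains either step.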